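This account rests on a few compounds, and the source may have more. Where it says the series, first, only, none or still open, it means among the compounds named here.

Measured compounds in a functional assay on HepG2 cells (Homo sapiens) for inhibition, read by MTT assay, with a stated time of 48 h, tested at 10 uM; a lower number here means less inhibition of growth, a higher number more inhibition of growth at the concentration tested:
compound 1 `O=C(/C=C/c1ccc(OCc2cn(Cc3ccccc3F)nn2)cc1)c1ccc(Br)cc1` gives 29%
compound 2 `O=C(/C=C/c1ccc(OCc2cn(Cc3cccc(F)c3)nn2)cc1)c1ccc(Br)cc1` gives 34%
compound 3 `COc1ccc(C(=O)/C=C/c2ccc(OCc3cn(Cc4ccccc4F)nn3)cc2)cc1` gives 33%

Compounds 1 and 2 share a core and differ by 3-fluorophenyl in place of 2-fluorophenyl on a saturated chain carbon bound to an aromatic nitrogen; this change gave a number 5 percentage points higher from compound 1 to compound 2 (within the scatter). Compound 3 differs from compound 1 by methoxy in place of bromo on an aromatic carbon, and that change gave a number 4 percentage points higher from compound 1 to compound 3 (within the scatter). All three numbers lie within the scatter of one another, so no order among them can be stated.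

Compound 4 `COc1ccc(C(=O)/C=C/c2ccc(OCc3cn(Cc4cccc(F)c4)nn3)cc2)cc1` has not yet been measured. It differs from compound 3 by 3-fluorophenyl in place of 2-fluorophenyl on a saturated chain carbon bound to an aromatic nitrogen, the same change, at the same place, as from compound 1 to compound 2. On that single precedent the step from compound 3 to compound 4 in this assay is expected to be a number 4 percentage points higher from compound 3 to compound 4 (within the scatter), small and within the scatter. Compound 4 is therefore estimated at 37%, with a likely range from 27% to 48%.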

Compound 4, percent growth inhibition at one concentration: 22%
For compound 4 the middle estimate is 15 percentage points above the measured one, and the stated range ends above it.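

The change from 2-fluorophenyl to 3-fluorophenyl gave a number 11 percentage points lower from compound 3 to compound 4 (beyond the scatter) in this assay, so it did not carry over unchanged from the core of compound 1 to the core of compound 3: the same change on two cores in this assay, a number 5 percentage points higher (within the scatter) from compound 1 to compound 2 and a number 11 percentage points lower (beyond the scatter) from compound 3 to compound 4, 16 percentage points apart, beyond the scatter of two such steps. Methoxy in place of bromo, giving a number 12 percentage points lower from compound 2 to compound 4 (beyond the scatter), likewise depended on the core it was placed on: the same change on two cores in this assay, a number 4 percentage points higher (within the scatter) from compound 1 to compound 3 and a number 12 percentage points lower (beyond the scatter) from compound 2 to compound 4, 16 percentage points apart, beyond the scatter of two such steps. Among the compounds shown here, both gaps rest on the single value of compound 4, so they show that the two changes do not simply add in these four compounds, but they give no general rule and no cause.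

Still open, from the compounds shown here alone, is whether the same dependence appears with an unsubstituted phenyl in place of the fluorophenyl groups. Also open, going by these compounds, is how an amine or a carboxylic acid would behave in place of bromo or methoxy.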